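The compounds below may be only part of what the source reports. "The series", "measured", "known", "first", "only" and "open" are said of these compounds alone.

Compound 1 `CC(C)N(Cc1cccc(OCCCCCC(=O)O)c1)C(=O)c1ccc(-c2cccc(Cl)c2)cc1` opens the series. In an ADME assay on BJ cells (Homo sapiens) for cytotoxicity, read by CellTiter-Glo and resazurin assay, with a stated time of 72 h (a lower number here means that less compound is needed, a higher number that more compound is needed for the effect), compound 1 gives > 21900 nM, which is a limit of the assay and not a number. Compound 2 `CCOC(=O)CCCCCOc1cccc(CN(C(=O)c2ccc(-c3cccc(OCc4ccccc4)c3)cc2)C(C)C)c1` is the second compound with a value. In this assay compound 2 gives > 26000 nM, again a limit rather than a number. Among the compounds with values here, compound 2 therefore stands at a limit, as does the one other value shown: the limit of > 21900 nM in this assay, at which 1 of the 2 values shown sits, and (the limit of > 26000 nM in this assay, at which 1 of the 2 values shown sits). Compound 3 `CCOC(=O)CCCCCOc1cccc(CN(C(=O)c2ccc(-c3cccc(Cl)c3)cc2)C(C)C)c1` differs from compound 2 by chloro in place of benzyloxy on an aromatic carbon. Within the data shown here, no pair of measured compounds differs in a single place, so no measured step is at hand to size this change. Compound 3 is expected to give 26000 nM, between 10000 nM and 60000 nM, most probably again reported as a limit. The expected step of a number no higher from compound 2 to compound 3 (the limit leaves the size open) is thus none beyond the scatter.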

Compound 3, half-maximal effective concentration: > 18400 nM
Compound 3 was reported as a limit; the forecaster's own chance of this, stated with the estimate: 80%; the middle value lies beyond the limit too.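

In this assay compound 1, compound 2 and compound 3 are all reported as limits, so neither the step from compound 2 to compound 3 nor that from compound 1 to compound 3 can be read. The compounds shown leave open what concentration would give the half-maximal effect for any of them.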